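This account rests on a few compounds, and the source may have more. Where it says the series, first, only, none or still open, it means among the compounds named here.

Going by the values given here, in a toxicity assay on Huh-7.5 cells (Homo sapiens) for inhibition, read by MTT assay, with a stated time of 96 h (a lower number here means that less compound is tolerated, a higher number that more compound is tolerated), compound 1 (`CN1CCN(Cc2ccc(NC(=O)c3ccc(OCCCCl)c(Cl)c3)cc2C(F)(F)F)CC1`) gives 4100 nM and compound 2 (`CN1CCN(Cc2ccc(NC(=O)c3ccc(OCCCCl)c(N)c3)cc2C(F)(F)F)CC1`) gives 12900 nM in this set, with a 3.1-fold higher number from compound 1 to compound 2 (0.50 log units; beyond the scatter) as the only step beyond the scatter. Compound 3 (`CN1CCN(Cc2ccc(NC(=O)c3ccc(OCCCCl)c([N+](=O)[O-])c3)cc2C(F)(F)F)CC1`) gives 6800 nM and lies within the scatter of both others, through a 1.7-fold higher number from compound 1 to compound 3 (0.22 log units; within the scatter) and a 1.9-fold lower number from compound 2 to compound 3 (0.28 log units; within the scatter) as the two steps that connect it.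

The move to compound 4 (`CN1CCN(Cc2ccc(NC(=O)c3ccc(OCCCCl)c(C(F)(F)F)c3)cc2C(F)(F)F)CC1`) is trifluoromethyl in place of nitro on an aromatic carbon in short: trifluoromethyl in place of nitro on an aromatic carbon, ortho to a 3-chloropropoxy group. Among the compounds with values here, no measured step involves trifluoromethyl, so any guide is indirect. The nearest is the exchange of chloro for nitro at this carbon, a 1.7-fold higher number from compound 1 to compound 3 (0.22 log units; within the scatter) in size, which stayed small. Only the amino group of compound 2 moved the number beyond the scatter, and that step was modest.

No step beyond the scatter is therefore expected in this assay, and the estimated step is a 1.2-fold lower number from compound 3 to compound 4 (0.09 log units; within the scatter) (expected, not measured). Compound 4 is estimated at 5500 nM (expected range 2500 nM to 11000 nM).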

Compound 4, half-maximal cytotoxic concentration: 13400 nM
For compound 4 the middle estimate is 2.4-fold (0.39 log units) below the measured one, outside the stated range (above it).
By their numbers in this assay, from the lowest: compounds 1, 3, 2 and 4 (each within the scatter of the next, the first and the last beyond it).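

In this assay, going by these compounds alone, trifluoromethyl on this aromatic carbon, ortho to a 3-chloropropoxy group, gives a second modest step beyond the scatter from the chloro compound (a 3.3-fold higher number from compound 1 to compound 4 (0.51 log units; beyond the scatter)), so amino is no longer the only group to do so. Trifluoromethyl lies within the scatter of both amino (a 1.0-fold higher number from compound 2 to compound 4 (0.02 log units; within the scatter)) and nitro (a 2.0-fold higher number from compound 3 to compound 4 (0.29 log units; within the scatter)), so these three groups cannot be separated here, and compound 3 keeps any split from chloro from being general, as it also lies within the scatter of compound 1. The compounds shown offer no measurement that would account for these steps.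

Open, on these data alone, is where a nitrile, a methoxy group or a carboxylic acid on this carbon would fall relative to chloro and trifluoromethyl. Also open, as far as these compounds go, is whether the step from chloro to trifluoromethyl holds with a longer chain in place of the 3-chloropropoxy group.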